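A few compounds are considered here, and "the series" means these few. Any claim that something is new, unique, unknown or untested is made for them only; others in the source may bear on it.

Working notes on the series in an ADME assay on the whole organism (Mus musculus, strain CD1) for metabolic stability, read by LC-MS, using cassette dosing, with a stated time of 24 h, at a dose of 0.4 mg/kg by the intravenous route; a lower number here means that the compound disappears faster, a higher number that the compound lasts longer.

Of the compounds shown here, three carry a number so far. Compound 1 `Cc1cn(-c2cc(NC(=O)c3ccc(C)c(Nc4nccc(-c5ccccc5)n4)c3)cc(N3CCNCC3)c2)cn1` gives 1.64 h. Compound 2 `Cc1cn(-c2cc(CN3CCN(C)CC3)cc(NC(=O)c3ccc(C)c(Nc4nccc(-c5ccccc5)n4)c3)c2)cn1` gives 3.29 h. Compound 3 `Cc1cn(-c2cc(NC(=O)c3ccc(C)c(Oc4ccccc4)c3)cc(C(F)(F)F)c2)cn1` gives 2.15 h. Between these, compound 3 sits with the second highest number of the three: its nearest neighbour is compound 1, its furthest is compound 2, and both gaps are within the scatter, so no order among the three can be read from the numbers.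

The next compound, compound 4 `Cc1cn(-c2cc(NC(=O)c3ccc(C)c(Oc4ccccc4)c3)cc(N3CCN(C)CC3)c2)cn1`, is not yet measured. It differs from compound 3 in one place: 4-methylpiperazin-1-yl in place of trifluoromethyl on an aromatic carbon.

Among the compounds with values here, the only measured step that bears on this change is a 2.0-fold higher number from compound 1 to compound 2 (0.30 log units; within the scatter), where a piperazine-containing group was exchanged for another on the same kind of position; that step stayed within the scatter. Nothing measured here follows the exchange of a trifluoromethyl for a 4-methylpiperazin-1-yl directly, and the three numbers in this assay all lie within the scatter of one another. On that basis no step beyond the scatter is expected in this assay for compound 4; the expected step is a 1.1-fold higher number from compound 3 to compound 4 (0.03 log units; within the scatter), essentially flat. Compound 4 is therefore estimated at 2.3 h, with a range from 1.2 h to 4.5 h.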

Compound 4, half-life: 7.36 h
For compound 4 the middle estimate is 3.2-fold (0.51 log units) below the measured one; the measured number lies above the stated range.
By their numbers in this assay, from the lowest: compounds 1, 3 and 2 (each within the scatter of the next); then compound 4.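

In this assay, the exchange of trifluoromethyl for 4-methylpiperazin-1-yl, on an aromatic carbon meta to a 4-methyl-1H-imidazol-1-yl group, gives a 3.4-fold higher number from compound 3 to compound 4 (0.53 log units; beyond the scatter), so the number in this series does respond to the group at this position. Within the data shown here, the only earlier step, a 2.0-fold higher number from compound 1 to compound 2 (0.30 log units; within the scatter), exchanged one piperazine-containing group for another on the core of compound 1 and could not show this; the new step instead replaces a group without a ring by one with a six-membered non-aromatic ring, and it is the first to lie beyond the scatter. Nothing measured on these compounds accounts for the step.

One exchange cannot separate the removal of trifluoromethyl from the arrival of the piperazine ring or its N-methyl group, so a plain hydrogen, a morpholine ring, an unsubstituted piperazine or an open-chain dimethylamino group at this position on the core of compound 3 would be needed to tell these apart. Whether the same exchange carries over to the core of compound 1 also stays open, since no trifluoromethyl counterpart on that core is shown.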